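A few compounds are considered here, and "the series" means these few. Any claim that something is new, unique, unknown or untested is made for them only; others in the source may bear on it.

Compound 1 `O=C([C@@H]1C[C@@H]1F)N1CC2CC(C1)N2`: 88 nM
Compound 2 `C[C@@H]1C[C@H]1C(=O)N1CC2CC(C1)N2`: 51 nM

In an assay on CHO cells for agonist activity at Neuronal acetylcholine receptor; alpha3/alpha6/beta2/beta3 (Homo sapiens), read by FLIPR and calcium flux (on this read-out higher numbers stand for an effect only at larger amounts of compound and lower numbers for an effect already at smaller amounts), compound 1 gives 88 nM and compound 2 gives 51 nM. For the measured compounds named here, compound 2 has the lower of the two numbers, but the only measured step, a 1.7-fold lower number from compound 1 to compound 2 (0.24 log units; within the scatter), lies within the scatter, so the two compounds cannot be told apart on this read-out.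

Compound 3 `C[C@H]1C[C@@H]1C(=O)N1CC2CC(C1)N2` keeps every atom and bond of compound 2; the difference is purely in how the ring carbons are drawn: the two compounds have the same atoms and bonds; at least one stereo element is drawn with a configuration in one of them and without one in the other: 2 of 4 stereo elements differ; a stereocentre at a saturated ring carbon is drawn R in compound 2 and S in compound 3; a stereocentre at a saturated ring carbon is drawn R in compound 2 and S in compound 3. Going by the values given here, the single measured step swapped one group for another and says nothing about a change of configuration, so no measured step bears on this move. Mirror-image pairs of this kind can agree or can differ strongly in either direction, and nothing here points one way. Compound 3 is therefore estimated at 90 nM in this assay, with a wide range from 15 nM to 600 nM, which corresponds to an expected step of a 1.8-fold higher number from compound 2 to compound 3 (0.25 log units; within the scatter).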

Compound 3, half-maximal effective concentration: 3800 nM
Compound 3: the middle estimate sits 42-fold (1.63 log units) below what was measured, and the stated range ends below it.
By their numbers in this assay, from the lowest: compounds 2 and 1 (each within the scatter of the next); then compound 3.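

At this position, the drawn configuration of the 2-methylcyclopropyl group matters far more than the earlier group swap suggested: with the same atoms and bonds, this assay shows a 75-fold higher number from compound 2 to compound 3 (1.87 log units; beyond the scatter). The change of group alone did not predict this, since compound 3 carries the same 2-methylcyclopropyl group that left compound 2 within the scatter of compound 1, yet it shows a 43-fold higher number from compound 1 to compound 3 (1.64 log units; beyond the scatter). The one recorded basis for the gap between the two methyl compounds is a matter of stereochemistry: the fact that one of compounds 2 and 3 is drawn with a defined configuration and the other without, at the place where they differ

As far as these compounds go, it remains open whether the 2-fluorocyclopropyl group is equally sensitive to its configuration. From the compounds shown here alone, it is also open where a plain cyclopropyl or a 2-ethylcyclopropyl group would fall on this scale.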